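This account rests on a few compounds, and the source may have more. Where it says the series, first, only, none or still open, it means among the compounds named here.

Compound 1 `CCCCN(C)C(=O)OCc1c(-c2ccc(O[C@H]3CCC[C@H](C(=O)O)C3)c(C)n2)nnn1C` is the starting point of this account. For the measured compounds named here, in an ADME assay on the whole organism (plasma, Homo sapiens) for protein binding, read by LC-MS, with a stated time of 24 h (on this read-out lower numbers stand for a smaller free fraction and higher numbers for a larger free fraction), compound 1 gives 0.026, the highest of the three numbers measured so far. Compound 3 `Cc1noc(-c2ccc(O[C@H]3CCC[C@H](C(=O)O)C3)cc2)c1CNC(=O)OCc1ccccc1` gives 0.005 in this assay, a gap beyond the scatter, and compound 2 `CN(CC1CCC1)C(=O)OCc1c(-c2ccc(O[C@H]3CCC[C@H](C(=O)O)C3)c(C(F)F)n2)nnn1C` gives 0.001, the lowest of the three. Compound 4 `Cc1nc(-c2nnn(C)c2COC(=O)N(C)CC2CCCC2)ccc1O[C@H]1CCC[C@H](C(=O)O)C1` differs from compound 1 in one place: cyclopentyl in place of propyl on a saturated chain carbon bound to an amide-type nitrogen. Going by the values given here, no measured pair shows this exact change, so its size is unknown from the data. A downward step a 2.6-fold lower number from compound 1 to compound 4 (0.41 log units; beyond the scatter) beyond the scatter is nevertheless expected, because the values of compound 2 at 0.001 and compound 3 at 0.005 show how low this series already reaches. Compound 4 is therefore estimated at 0.01, with a range from 0.004 to 0.022.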

Compound 4, unbound fraction: 0.012
Estimate against measurement, compound 4: 1.2-fold (0.08 log units) below; low and high end bracket the measured number.
By their numbers in this assay, from the lowest: compound 2; then compound 3; then compound 4; then compound 1.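

In this assay, for the compounds shown here, cyclopentyl in place of propyl on a saturated chain carbon bound to an amide-type nitrogen gives a 2.2-fold lower number from compound 1 to compound 4 (0.34 log units; beyond the scatter), the first change in one place in this account. It shows that this position alone can move the free fraction, and that here the carbon-only ring goes with the smaller free fraction. Nothing at hand gives a reason for this step.

This single pair does not separate the closing of the ring from the two added carbons. On these data alone, how a hydroxyl, an ether oxygen or an amine on this chain would read remains open.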